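The compounds below may be only part of what the source reports. "The series", "measured", "known", "first", "only" and "open" are said of these compounds alone.

Measured compounds in an ADME assay on HEL cells (Homo sapiens) for cytotoxicity, with a stated time of 3 days; a higher number here means that more compound is tolerated, a lower number that less compound is tolerated:
compound 1 `CCC1(Cc2ccccc2)OS(=O)(=O)C=C1OCC(=O)OC`: > 400000 nM
compound 2 `CCC1(Cc2ccccc2)OS(=O)(=O)C=C1OCc1ccc(Cl)cc1`: >= 50000 nM
compound 3 `CCC1(Cc2ccccc2)OS(=O)(=O)C=C1OCC=C(C)C`: 400000 nM

In this assay compound 1 gives > 400000 nM, which is a limit of the assay and not a number (the limit of > 400000 nM in this assay, at which 1 of the 3 values shown sits). Compound 2 gives >= 50000 nM, again a limit rather than a number (the limit of >= 50000 nM in this assay, at which 1 of the 3 values shown sits). Among the compounds with values here, compound 3 gives 400000 nM, the only plain number among the three values shown, and therefore the anchor for the series. The three steps between the measured compounds carry no readable size: a number no higher from compound 1 to compound 3 (the limit leaves the size open), a step that the two limits leave unreadable from compound 1 to compound 2 and a step that the limit leaves unreadable from compound 2 to compound 3. All that can be said is that variation at the saturated chain carbon bound to the oxygen on the unsaturated carbon has kept every compound at or near the upper edge of what this assay reports.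

Compound 4 `CCC1(Cc2ccccc2)OS(=O)(=O)C=C1OC(=O)c1ccccc1` is the next compound to be measured. It differs from compound 3 by benzoyl in place of 3-methylbut-2-en-1-yl on an oxygen on an unsaturated carbon. Within the data shown here, no measured step exchanges a group directly on that oxygen, so none bears on this change with a readable size; the closest comparisons are the three unreadable steps above. The expectation is therefore a step no larger than the scatter, a 1.3-fold lower number from compound 3 to compound 4 (0.12 log units; within the scatter), with compound 4 staying near the ceiling of this assay. Compound 4 is estimated at 300000 nM, expected to fall between 100000 nM and 400000 nM.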

Compound 4, minimum cytotoxic concentration: > 400000 nM
Compound 4 ended at the assay's limit; the forecaster's own chance of this, stated with the estimate: 40%; middle value at least 1.3-fold (0.12 log units) away from the limit.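

Benzoyl is the first group shown to place a carbonyl directly on the oxygen on an unsaturated carbon, and in this assay compound 4 gives > 400000 nM, which is a limit and not a number. This exchange for 3-methylbut-2-en-1-yl is read as a number no lower from compound 3 to compound 4 (the limit leaves the size open), while the steps to compound 4 from compound 1 and compound 2 cannot be read; no fall in the tolerated concentration appears with the carbonyl or with the aromatic ring brought in by benzoyl. Compound 4 therefore joins compound 1 at the upper edge of the reported range: the limit of > 400000 nM in this assay, at which 2 of the 4 values shown sit.

With compound 3 as the only compound giving a plain number, the size of any difference among these groups on that oxygen remains unknown, and the compounds shown do not establish a true ranking. On these data alone, it also remains open whether an amine or a carboxylic acid in place of benzoyl would keep the number at this upper edge, or whether either would bring a readable step.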